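Changing the Aryl Group on the Aromatic Nitrogen

The source may report more compounds than this note shows. Statements on the series, on what has been measured and on what is new or still open speak of the compounds shown alone.

Measured compounds:
compound 1 `N#Cc1ccccc1-n1cc(COc2cccc(NC(=O)Nc3ccc(Cl)c(C(F)(F)F)c3)c2)nn1`, 1970 nM
compound 2 `O=C(Nc1cccc(OCc2cn(-c3cccc(I)c3)nn2)c1)Nc1ccc(Cl)c(C(F)(F)F)c1`, 4780 nM

In a functional assay on HepG2 cells (Homo sapiens) for inhibition, read by MTT assay, with a stated time of 72 h (on this read-out lower numbers stand for stronger inhibition and higher numbers for weaker inhibition), compound 1 gives 1970 nM and compound 2 gives 4780 nM. Within the data shown here, compound 2 stands highest of the two numbers so far; its nearest neighbour is compound 1, and the step of a 2.4-fold higher number from compound 1 to compound 2 (0.38 log units; beyond the scatter) lies beyond the scatter. Compound 3 `O=C(Nc1cccc(OCc2cn(-c3ccc(C(F)(F)F)cc3)nn2)c1)Nc1ccc(Cl)c(C(F)(F)F)c1` has not yet been measured in this assay. It differs from compound 2 in one place: 4-(trifluoromethyl)phenyl in place of 3-iodophenyl on an aromatic nitrogen. Among the measured compounds shown here, the only measured step that bears on this change is the one at the same place, a 2.4-fold higher number from compound 1 to compound 2 (0.38 log units; beyond the scatter), which shows that exchanging the aryl group on the aromatic nitrogen moves the number modestly. For the measured compounds named here, with one such step and no pair containing the entering group, the data give no direction. The change is therefore expected to be small, a 1.5-fold lower number from compound 2 to compound 3 (0.17 log units; within the scatter). Compound 3 is estimated at 3200 nM, with a range from 1300 nM to 8000 nM.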

Compound 3, half-maximal inhibitory concentration: 1800 nM
Beside the measured number, compound 3's estimate is 1.8-fold (0.25 log units) above it, and the stated range covers the measured number.
By their numbers in this assay, from the lowest: compounds 3 and 1 (each within the scatter of the next); then compound 2.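

In this assay the exchange of 3-iodophenyl for 4-(trifluoromethyl)phenyl gives a 2.7-fold lower number from compound 2 to compound 3 (0.42 log units; beyond the scatter) and so shows that a change at this position can also lower the number. Among these compounds, the other new step, a 1.1-fold lower number from compound 1 to compound 3 (0.04 log units; within the scatter), lies within the scatter, so 2-cyanophenyl and 4-(trifluoromethyl)phenyl are not told apart here, while 3-iodophenyl is the only one of the three groups set apart from both others, and only compound 1 and compound 3 stay level. Nothing given here accounts for these steps.

The three aryl groups differ both in their substituent and in where it sits, so the two influences cannot be separated. On these data alone, it remains open how the number would respond to 4-iodophenyl, to an amine or a carboxylic acid on the phenyl ring, or to a longer alkyl chain in place of the aryl group.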